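The source may hold more compounds than are shown below. What is called first, only, known or untested is meant among the compounds shown, and "the series" means these compounds.

Measured compounds in a functional assay on RAW264.7 cells (Mus musculus) for inhibition; on this read-out higher numbers stand for weaker inhibition and lower numbers for stronger inhibition:
Compound 1 `O=C1/C(=C/c2ccccc2Cl)CCc2cc(O)ccc21` gives 1910 nM
Compound 2 `O=C1/C(=C/c2ccccc2Br)CCc2cc(O)ccc21` gives 1070 nM
Compound 3 `O=C1/C(=C/c2cccc(Cl)c2)CCc2ccc(O)cc21` gives 210 nM

Compound 2 differs from compound 1 by bromo in place of chloro on an aromatic carbon and the result is a 1.8-fold lower number from compound 1 to compound 2 (0.25 log units; within the scatter). Compound 3 has the same atoms as compound 1 joined differently; the difference between the two cores is not broken down here. Compound 3 is the most potent of the three, its steps to compound 1 and compound 2 both lying beyond the scatter.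

Compound 4 `O=C1/C(=C/c2cccc(Br)c2)CCc2ccc(O)cc21` differs from compound 3 by bromo in place of chloro on an aromatic carbon. This is the same kind of change as that from compound 1 to compound 2, but the place is not the same: there the halogen sits ortho to a large group, here meta to a large group. Going by the values given here, only one earlier example exists, so the expectation rests on it alone. The step is expected to be a 1.4-fold lower number from compound 3 to compound 4 (0.15 log units; within the scatter), within the scatter, because a 1.8-fold lower number from compound 1 to compound 2 (0.25 log units; within the scatter) was itself within the scatter. Compound 4 is expected to give about 150 nM, between 60 nM and 400 nM.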

Compound 4, half-maximal inhibitory concentration: 480 nM
Compound 4: middle estimate off by 3.2-fold (0.51 log units), on the low side; measured number above the stated range.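

In this assay, bromo in place of chloro on an aromatic carbon weakens inhibition modestly on the core of compound 3 (a 2.3-fold higher number from compound 3 to compound 4 (0.36 log units; beyond the scatter)). The change therefore does not carry over as a fixed step between these two cores: the same change on two cores in this assay, a 1.8-fold lower number (0.25 log units; within the scatter) from compound 1 to compound 2 and a 2.3-fold higher number (0.36 log units; beyond the scatter) from compound 3 to compound 4, 4.1-fold (0.61 log units) apart, beyond the scatter of two such steps. This rests on a single pair per core, and the halogen also sits in a different place in each pair, so the data cannot separate the role of the core from that of the halogen's place.

The compounds shown leave open how fluoro, methoxy or an amine would compare with chloro and bromo in the same place on the core of compound 3. Also open, on these data alone, is whether either direction of the step would hold on a third core.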